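Fluorophenyl shift from compound 2 to compound 3

A few compounds are considered here, and "the series" means these few. Any claim that something is new, unique, unknown or untested is made for them only; others in the source may bear on it.

In a functional assay on NCI-H1975 cells (Homo sapiens) for antiproliferative activity, read by CellTiter-Glo, with a stated time of 96 h (on this read-out higher numbers stand for weaker inhibition and lower numbers for stronger inhibition), compound 1 `COc1ccc(-c2nsc3c2NC(=O)CC3c2cccc(OC)c2)cc1` gives 1980 nM. Compound 2 `COc1ccc(-c2nsc3c2NC(=O)CC3c2cccc(F)c2)cc1` gives > 2000 nM, which is a limit and not a number, placing it at the limit of > 2000 nM in this assay, at which 1 of the 2 values shown sits. Compound 3 `COc1ccc(-c2nsc3c2NC(=O)CC3c2ccc(F)cc2)cc1` has 4-fluorophenyl in place of 3-fluorophenyl on a saturated ring carbon. Among the measured compounds shown here, the only measured step nearby is a number no lower from compound 1 to compound 2 (the limit leaves the size open), with fluoro in place of methoxy on an aromatic carbon, and it gives no size to carry over. No change beyond the scatter is therefore expected in this assay, in either direction. The expected result is a step that the limit leaves unreadable from compound 2 to compound 3. Compound 3 is estimated at 2300 nM, with an expected range of 1000 nM to 5000 nM.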

Compound 3, half-maximal inhibitory concentration: > 2000 nM
Compound 3 gave a limit, no number; the forecaster's own chance of this, stated with the estimate: 60%; the middle value is on the limit's open side.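

With 4-fluorophenyl in place of 3-fluorophenyl on the saturated ring carbon, this assay still returns no number, so a second fluorophenyl now sits at the limit of the read-out: the limit of > 2000 nM in this assay, at which 2 of the 3 values shown sit.

The step from compound 2 to compound 3 cannot be read.

Going by these compounds, how far compound 2 and compound 3 lie past the limit stays open, so the size of the change between 3-fluorophenyl and 4-fluorophenyl remains unknown. Putting 4-fluorophenyl in place of 3-methoxyphenyl on the saturated ring carbon gives a number no lower from compound 1 to compound 3 (the limit leaves the size open).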